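Phenyl for Pyridin-4-yl: Expected Effect on Cell Growth

The compounds below may be only part of what the source reports. "The series", "measured", "known", "first", "only" and "open" are said of these compounds alone.

Compound 1 `COc1cc(OC)c2c(=O)cc(/C=C/c3ccncc3)oc2c1` was tested in a functional assay on SKHep cells (Homo sapiens) for antiproliferative activity, read by MTT assay, with a stated time of 12 h; on this read-out lower numbers stand for stronger inhibition and higher numbers for weaker inhibition. In this assay compound 1 gives > 40000 nM, which is a limit of the assay rather than a number. Compound 2 `COc1ccc2c(=O)cc(/C=C/c3ccc(OC(F)(F)F)cc3)oc2c1` also gives only a limit in this assay, > 40000 nM. Both results fall under (the limit of > 40000 nM in this assay, at which 2 of the 2 values shown sit). Compound 3 `COc1cc(OC)c2c(=O)cc(/C=C/c3ccccc3)oc2c1` differs from compound 1 by phenyl in place of pyridin-4-yl on a double-bonded chain carbon bound to a double-bonded chain carbon. For the measured compounds named here, no measured pair shows what this change does here, so the expected step is a number no higher from compound 1 to compound 3 (the limit leaves the size open), nothing beyond the usual scatter. Compound 3 is therefore estimated at 40000 nM, within 10000 nM to 100000 nM, most likely reported again only as a limit.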

Compound 3, half-maximal inhibitory concentration: 26000 nM
For compound 3 the middle estimate is 1.5-fold (0.19 log units) above the measured one, and the stated range covers the measured number.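

In this assay, the change to phenyl on a double-bonded chain carbon bound to a double-bonded chain carbon gives an at least 1.5-fold lower number from compound 1 to compound 3 (0.18 log units; that floor lies within the scatter). From the compounds shown here alone, that step has only a floor, so its true size stays unknown, and the floor alone does not show a real gain. Compound 3 is still the only compound shown with a number rather than a limit: the limit of > 40000 nM in this assay, at which 2 of the 3 values shown sit.

Going by these compounds, whether an amine or a carboxylic acid on the phenyl would shift the number remains open. So does the effect of a pyridin-3-yl group at this place.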